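A few compounds are considered here, and "the series" means these few. Any claim that something is new, unique, unknown or untested is made for them only; others in the source may bear on it.

Measured so far:
- compound 1, `O=C(O)CC(O)(CSCCCCCCc1ccc(Cl)cc1Cl)C(=O)O`: 3300 nM
- compound 2, `O=C(O)CC(O)(CSCCCCCCc1c(Cl)cc(Cl)cc1-c1ccccc1)C(=O)O`: 10000 nM

In an assay on isolated protein for inhibition of ATP-citrate synthase (Rattus norvegicus) (on this read-out higher numbers stand for weaker inhibition and lower numbers for stronger inhibition), compound 1 gives the lowest of the two numbers, so among the measured pair it shows the stronger inhibition. Its nearest neighbour is compound 2, reached by a 3.0-fold higher number from compound 1 to compound 2 (0.48 log units; beyond the scatter) through the substitution of phenyl for hydrogen on an aromatic carbon.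

Compound 3, `O=C(O)CC(O)(CSCCCCCCc1ccc(F)cc1F)C(=O)O`, has not yet been measured. It differs from compound 1 by 2,4-difluorophenyl in place of 2,4-dichlorophenyl on a saturated chain carbon, six bonds along the chain from a sulfur. Among the compounds with values here, the only measured step, from compound 1 to compound 2, concerns a different kind of change, an added ring rather than a swap of halogens, so it gives no direct guide to this one. What it does show is that an alteration of the aromatic ring at the far end of the chain can move this assay by a modest amount. Within the data shown here, with no closer precedent, the expectation for compound 3 is a number near that of compound 1, with a step of about a 1.5-fold higher number from compound 1 to compound 3 (0.18 log units; within the scatter) that may well fall within the scatter. The estimated value for compound 3 is 5000 nM, within a range from 2000 nM to 15000 nM.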

Compound 3, inhibition constant: 270000 nM
Compound 3: the middle estimate sits 54-fold (1.73 log units) below what was measured; the whole stated range lies below it.
By their numbers in this assay, from the lowest: compound 1; then compound 2; then compound 3.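

Moving to this assay, placing 2,4-difluorophenyl in place of 2,4-dichlorophenyl on a saturated chain carbon, six bonds along the chain from a sulfur, gives an 82-fold higher number from compound 1 to compound 3 (1.91 log units; beyond the scatter) and so weakens inhibition far more than adding a phenyl did in a 3.0-fold higher number from compound 1 to compound 2 (0.48 log units; beyond the scatter) on the same ring. The two groups match in every count compared here, with the same number of heavy atoms, one aromatic ring of carbon only, no hydrogen-bond donors or acceptors and no net charge, so those counts cannot separate them and the halogen is the only thing that differs. This shows that the choice of halogen on this ring can matter greatly in this series, but no measurement offered here accounts for the size of the loss.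

The compounds shown leave open whether the chlorine at one ring position matters more than the chlorine at the other, which a phenyl carrying a single chlorine would help to settle. They also leave open whether a phenyl carrying two bromine atoms would keep, improve or lose the inhibition seen with the dichlorinated ring.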